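From methyl to methoxy in a cytotoxicity read-out

This account rests on a few compounds, and the source may have more. Where it says the series, first, only, none or still open, it means among the compounds named here.

Compound 1 `N#Cc1cccc(Sc2cccc(N)c2C#N)c1` gives 80000 nM as a number
Compound 2 `Cc1cc(C)cc(Sc2cccc(N)c2C#N)c1` gives > 2000 nM as a limit

In a functional assay on MT4 cells (Homo sapiens) for cytotoxicity (on this read-out lower numbers stand for stronger inhibition and higher numbers for weaker inhibition), compound 2 is recorded at > 2000 nM as a limit and not as a number. The change to compound 3 `COc1cc(C)cc(Sc2cccc(N)c2C#N)c1` puts methoxy in place of methyl on an aromatic carbon and leaves the rest of the molecule as it is. Among the compounds with values here, no measured pair in this small set isolates such a change. Within the data shown here, the expectation therefore leans on compound 1, which gives 80000 nM in this assay as the only number available. The expected move is a step that the limit leaves unreadable from compound 2 to compound 3 toward weaker inhibition, and the assay may again report only a limit. For compound 3 the estimated value is 30000 nM with an expected range from 5000 nM to 150000 nM in this read-out.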

Compound 3, half-maximal inhibitory concentration: 10000 nM
Beside the measured number, compound 3's estimate is 3.0-fold (0.48 log units) above it; measured number inside the range.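

Within the data shown here, no step from compound 2 to compound 3 can be read, because compound 2 is recorded only as a limit and not as a number: the limit of > 2000 nM in this assay, at which 1 of the 3 values shown sits. The compounds shown leave open whether, and by how much, methoxy in place of methyl on an aromatic carbon shifts this read-out.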